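Hydrazide series: chloro for methoxy on the benzylidene ring

The compounds below may be only part of what the source reports. "The series", "measured", "known", "first", "only" and "open" are said of these compounds alone.

Measured compounds:
compound 1 `Cc1ccc(C(=O)N/N=C/c2ccccc2O)c(O)c1` 1020 nM
compound 2 `COc1cccc(/C=N/NC(=O)c2ccc(C)cc2O)c1` 20600 nM
compound 3 `Cc1ccc(C(=O)N/N=C/c2ccccc2F)c(O)c1` 42100 nM

Three compounds share the core and differ only on the aldehyde-derived ring. In a functional assay (Mus musculus, strain BALB/C) for inhibition, read by MTT assay, with stated times of 24 h and 72 h (on this read-out higher numbers stand for weaker inhibition and lower numbers for stronger inhibition), compound 1 gives the lowest number. Compound 2 stands second highest of the three, its nearest neighbour being compound 3, and compound 1 lying far below it. Among the measured compounds shown here, the single one-place step in hand is a 41-fold higher number from compound 1 to compound 3 (1.62 log units; beyond the scatter), a large weakening when a hydroxy group is exchanged for fluoro.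

Compound 4 `Cc1ccc(C(=O)N/N=C/c2cccc(Cl)c2)c(O)c1` is not yet measured. It differs from compound 2 by chloro in place of methoxy on an aromatic carbon. For the measured compounds named here, no measured step covers a chloro group or a methoxy group directly, so the change from compound 2 to compound 4 has no close precedent. The step from compound 1 to compound 3 shows that removing an oxygen-bearing group can cost a great deal, but that step concerns a different group. Compound 2 already sits among the higher numbers, so an expectation near its value, perhaps somewhat higher, seems reasonable for compound 4, with wide uncertainty.

Compound 4 is therefore expected to give 26000 nM in this assay, within 8000 nM to 85000 nM, which corresponds to an estimated step of a 1.3-fold higher number from compound 2 to compound 4 (0.10 log units; within the scatter).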

Compound 4, half-maximal inhibitory concentration: 24400 nM
Estimate against measurement, compound 4: 1.1-fold (0.03 log units) above; measured number inside the range.
By their numbers in this assay, from the lowest: compound 1; then compounds 2, 4 and 3 (each within the scatter of the next, the first and the last beyond it).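

In this assay, the exchange of methoxy for chloro on this aromatic carbon, meta to a large group, gives a 1.2-fold higher number from compound 2 to compound 4 (0.07 log units; within the scatter). At this place the two groups cannot be told apart on this read-out, although methoxy carries a hydrogen-bond acceptor and chloro carries none; the large step of a 41-fold higher number from compound 1 to compound 3 (1.62 log units; beyond the scatter) therefore does not extend to every loss of an oxygen-bearing group in the series, though that step concerns a different exchange at a different place. Nothing measured here accounts for the two groups reading alike.

The compounds shown leave open whether this place tolerates groups of another kind, such as an amine, a carboxylic acid or a longer chain, or whether the numbers would then move as far as they do in the step from hydroxy to fluoro. Also open, as far as these compounds go, is whether chloro and methoxy would still read alike on the other aromatic carbons of this ring, since the pair in hand covers one place only.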